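Chloro in place of fluoro on the aryl ring of compound 1

A few compounds are considered here, and "the series" means these few. Any claim that something is new, unique, unknown or untested is made for them only; others in the source may bear on it.

Measured so far:
compound 1, `CN1C[C@@H](c2ccccc2)[C@@]2(Cc3ccccc3C2=O)[C@@]12C(=O)Nc1ccccc12`: 40%
compound 2, `CN1C[C@@H](c2ccc(F)cc2)[C@@]2(Cc3ccccc3C2=O)[C@@]12C(=O)Nc1ccccc12`: 21.2%
compound 3, `CN1C(=O)[C@@]2(c3ccccc31)N(C)C[C@@H](c1ccco1)[C@@]21Cc2ccccc2C1=O`: 33.1%

In a functional assay on the whole organism (strain Wister albino) for inhibition, with Rattus norvegicus as the target, read by paw edema, with stated times of 1 h and 2 h, at a dose of 50 mg/kg by the intraperitoneal route (a higher number here means more inhibition at the dose given (going by the name of the read-out), a lower number less inhibition), compound 1 holds the highest of the three numbers. Compound 3 sits nearest, and the gap between compound 1 and compound 3 is within the scatter, so nothing is read into it. For the measured compounds named here, the one change that has been measured on the aryl ring is fluoro in place of hydrogen on an aromatic carbon, and it gave a number 18.8 percentage points lower from compound 1 to compound 2 (beyond the scatter), a drop beyond the scatter.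

Compound 4, `CN1C[C@@H](c2ccc(Cl)cc2)[C@@]2(Cc3ccccc3C2=O)[C@@]12C(=O)Nc1ccccc12`, differs from compound 1 by chloro in place of hydrogen on an aromatic carbon. The step from compound 1 to compound 2 is the only measured one that bears on it, and it was modest and downward. A step of similar kind and size is therefore expected here, giving a number 13 percentage points lower from compound 1 to compound 4 (beyond the scatter) in this assay, most likely downward rather than none. For compound 4 the expected value in this assay is 27%, within a range from 14% to 42%.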

Compound 4, a percentage reported as inhibition, in the whole organism at one dose (the size of the read-out at that dose, not a potency): 28.4%
Estimate against measurement, compound 4: 1.4 percentage points below; low and high end bracket the measured number.
By their numbers in this assay, from the lowest: compounds 2, 4, 3 and 1 (each within the scatter of the next, the first and the last beyond it).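

In this assay, chloro in place of hydrogen on an aromatic carbon, para to a large group, gives a number 11.6 percentage points lower from compound 1 to compound 4 (beyond the scatter) and so goes the same way as the fluoro change: among the compounds shown, both halogens at this place lie beyond the scatter from the unsubstituted phenyl of compound 1. The two halogens themselves are not separated, since chloro in place of fluoro gives a number 7.2 percentage points higher from compound 2 to compound 4 (within the scatter) and compound 2 and compound 4 therefore cannot be ranked. Nothing shown accounts for either step.

On these data alone, whether the step belongs to halogens alone or to any group at this place stays open, and a methoxy group, an amine or a carboxylic acid there would address it. Also open, as far as these compounds go, is whether chloro elsewhere on the aryl ring gives a step of this kind.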